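The source may hold more compounds than are shown below. What is called first, only, known or untested is meant among the compounds shown, and "the series" means these compounds.

Measured in a functional assay on HL-60 cells (Homo sapiens) for antiproliferative activity, read by MTT assay, with a stated time of 72 h; on this read-out lower numbers stand for stronger inhibition and higher numbers for weaker inhibition:
- compound 1 `COc1cc(-n2ncnc2-c2ccc(C)cc2)cc(OC)c1OC`: 90 nM
- compound 2 `COc1ccc(-c2ncnn2-c2cc(OC)c(OC)c(OC)c2)cc1`: 120 nM
- compound 3 `COc1cc(-n2ncnc2-c2ccc(Cl)cc2)cc(OC)c1OC`: > 10000 nM (a limit of the assay, not a number)

Compound 3 stands at the limit of > 10000 nM in this assay, at which 1 of the 3 values shown sits. The next change gives compound 4 `COc1cc(-n2ncnc2-c2ccc(OC(F)(F)F)cc2)cc(OC)c1OC`, with trifluoromethoxy in place of chloro on an aromatic carbon, para to a large group.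

For the measured compounds named here, three measured steps bear on this place. Methoxy in place of methyl gives a 1.3-fold higher number from compound 1 to compound 2 (0.12 log units; within the scatter). Chloro gives a large step from either neighbour: an at least 110-fold higher number from compound 1 to compound 3 (2.04 log units; beyond the scatter), and an at least 83-fold higher number from compound 2 to compound 3 (1.92 log units; beyond the scatter). Going by the values given here, no measured step has trifluoromethoxy entering, so the direction is only tentative. An oxygen-linked group is tolerated here in compound 2 at 120 nM, so some recovery in this assay is expected, though probably not all the way. Compound 4 may also remain at the limit. The expected change is an at least 3.3-fold lower number from compound 3 to compound 4 (0.52 log units; beyond the scatter). Compound 4 is estimated at 3000 nM, with an expected range from 200 nM to 10000 nM.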

Compound 4, half-maximal inhibitory concentration: > 10000 nM
Compound 4: a limit, no number; the forecaster's own chance of this, stated with the estimate: 40%; middle value at least 3.3-fold (0.52 log units) away from the limit.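

In this assay compound 4 gives > 10000 nM, which is a limit of the assay and not a number. Trifluoromethyl in place of methyl on the oxygen gives an at least 83-fold higher number from compound 2 to compound 4 (1.92 log units; beyond the scatter), and trifluoromethoxy in place of methyl gives an at least 110-fold higher number from compound 1 to compound 4 (2.04 log units; beyond the scatter), so an oxygen-linked group at this place does not by itself keep the activity seen with compound 2. The step between compound 3 and compound 4 cannot be read, with both compounds at the same limit: the limit of > 10000 nM in this assay, at which 2 of the 4 values shown sit.

From the compounds shown here alone, what separates methyl and methoxy from chloro and trifluoromethoxy at this place remains open, as does the true potency of compound 3 and compound 4 beyond the limit. A fluoro, ethyl or dimethylamino group here would test how narrow the tolerated set is.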